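A few compounds are considered here, and "the series" means these few. Any claim that something is new, unique, unknown or untested is made for them only; others in the source may bear on it.

Going by the values given here, in an assay on MCF7 cells for inhibition of Serine-protein kinase ATM (Homo sapiens), read by immunofluorescence, with a stated time of 1 h (a higher number here means a weaker inhibitor, a lower number a stronger inhibitor), compound 2 `CCOC(=O)NCCCOc1cc2c(-n3nc(-c4ccccn4)nc3N)ncnc2cc1OC` gives 800 nM, the lowest of the two numbers measured so far, while compound 1 `COc1cc2ncnc(-n3nc(-c4ccccn4)nc3N)c2cc1OCc1ccccc1` gives 8600 nM. Among the compounds with values here, the only measured step is an 11-fold lower number from compound 1 to compound 2 (1.03 log units; beyond the scatter). Compound 3 `COc1cc2ncnc(-n3nc(-c4ccccn4)nc3N)c2cc1OCCCNC(=O)OC(C)C` differs from compound 2 by methyl in place of hydrogen on a saturated chain carbon bound to an oxygen next to a carbonyl group and a saturated chain carbon. Within the data shown here, that earlier step altered another part of the same chain and so bears only loosely on this smaller change, and no measured step addresses a change of this kind. For compound 3 the expected step is no change at the digits printed from compound 2 to compound 3 (within the scatter), nothing beyond the scatter. The estimate for compound 3 in this assay is 800 nM, between 400 nM and 1600 nM.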

Compound 3, half-maximal inhibitory concentration: 1000 nM
Compound 3: the middle estimate sits 1.3-fold (0.10 log units) below what was measured, and the stated range covers the measured number.
By their numbers in this assay, from the lowest: compounds 2 and 3 (each within the scatter of the next); then compound 1.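

In this assay, the change from ethoxycarbonyl to isopropoxycarbonyl gives a 1.3-fold higher number from compound 2 to compound 3 (0.10 log units; within the scatter), so methyl in place of hydrogen on this saturated chain carbon shifts the number by no more than the scatter. The isopropoxycarbonyl chain also retains the earlier drop, with an 8.6-fold lower number from compound 1 to compound 3 (0.93 log units; beyond the scatter), so that drop does not depend on ethoxycarbonyl alone. Nothing given here accounts for either result. Going by these compounds, whether tert-butoxy at this place, a longer chain, or an amine or carboxylic acid in place of the ethoxycarbonyl group would move the number beyond the scatter remains open.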